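Aminophenyl for methylpyrazole on a fused bicyclic core

The source may report more compounds than this note shows. Statements on the series, on what has been measured and on what is new or still open speak of the compounds shown alone.

Compound 1 `COC(=O)c1sc2cc(-c3cccs3)cnc2c1N`: 26900 nM
Compound 2 `COC(=O)c1sc2cc(-c3cnn(C)c3)cnc2c1N`: > 150000 nM
Compound 3 `COC(=O)c1sc2cc(-c3ccc(C(C)=O)cc3)cnc2c1N`: > 150000 nM

In a functional assay on MCF7 cells (Homo sapiens) for inhibition, read by sulforhodamine B assay, with a stated time of 48 h (a lower number here means a stronger inhibitor of growth, a higher number a weaker inhibitor of growth), compound 1 gives 26900 nM. For compound 2 the assay reports only a limit, > 150000 nM, namely (the limit of > 150000 nM in this assay, at which 2 of the 3 values shown sit). For compound 3 the assay likewise reports only a limit, > 150000 nM. Among the measured compounds shown here, the one measured step that reaches compound 2 is an at least 5.5-fold higher number from compound 1 to compound 2 (0.74 log units; beyond the scatter), so compound 2 stands at the weak end of what has been measured. The unmeasured compound 4 `COC(=O)c1sc2cc(-c3cccc(N)c3)cnc2c1N` differs from compound 2 by 3-aminophenyl in place of 1-methyl-1H-pyrazol-4-yl on an aromatic carbon. For the measured compounds named here, no measured step touches the 3-aminophenyl group; compound 1 shows that a small five-membered substituent at this place can give a measured number rather than a limit, while compound 3 shows that a six-membered carbon ring bearing a carbonyl substituent remains at the limit. The step is therefore expected to be an at least 1.8-fold lower number from compound 2 to compound 4 (0.27 log units; that floor lies within the scatter) at most, with a fair chance that only a limit is returned again. Compound 4 is estimated at 80000 nM, within 20000 nM to 200000 nM.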

Compound 4, concentration for 50% growth inhibition: > 150000 nM
Compound 4 ended at the assay's limit; the forecaster's own chance of this, stated with the estimate: 40%; at least 1.8-fold (0.27 log units) between middle value and limit.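

In this assay compound 4 returns only a limit, > 150000 nM. Among the compounds shown here, the one readable step is an at least 5.5-fold higher number from compound 1 to compound 4 (0.74 log units; beyond the scatter), so a six-membered carbon ring bearing an amine, like the one bearing a carbonyl substituent in compound 3, gives no measured number at this place on the shared core; the step from compound 2 to compound 4 cannot be read, as both ends are limits. Among the compounds shown, only the thiophen-2-yl group of compound 1 gives a number rather than a limit, and the series now sits mostly at the ceiling: the limit of > 150000 nM in this assay, at which 3 of the 4 values shown sit.

On these data alone, it remains open whether an unsubstituted phenyl ring or a furan-2-yl group at this place would return a number. As far as these compounds go, it is also open whether a carboxylic acid or an amide in place of the methyl ester would change this picture.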